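The source may hold more compounds than are shown below. What is called first, only, known or untested is meant among the compounds shown, and "the series" means these compounds.

Compound 1 `COc1ccc(/C=C\c2cc(OC)c(OC)c(OC)c2)cc1OCc1ccc(CN2CCCC[C@H]2C(=O)O)cc1` — in an ADME assay on HEK293 cells (Homo sapiens) for cytotoxicity, read by CCK-8 assay, with a stated time of 48 h (on this read-out higher numbers stand for weaker inhibition and lower numbers for stronger inhibition), compound 1 gives > 50000 nM, a limit of the assay rather than a number.
Compound 2 `COc1ccc(/C=C\c2cc(OC)c(OC)c(OC)c2)cc1OCc1ccc(CN2CCCC[C@@H]2C(=O)O)cc1` — in this assay compound 2 gives 42000 nM.

Compound 1 therefore stands at the edge of what this assay can report: only a limit is known for it, at the weak-inhibition end. Within the data shown here, the one measured step that bears on the question is an at least 1.1-fold lower number from compound 1 to compound 2 (0.07 log units; that floor lies within the scatter), and because the fact that compounds 1 and 2 differ only in the configuration as drawn it tells only that a change in drawn configuration leaves the read-out within the scatter; the step cannot be sized more closely because of the limit of > 50000 nM in this assay, at which 1 of the 2 values shown sits.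

Compound 3 `COc1ccc(/C=C\c2cc(OC)c(OC)c(OC)c2)cc1OCc1ccc(CN2CC[C@H](C(=O)O)C2)cc1` differs from compound 1 in another way: 3-carboxypyrrolidin-1-yl in place of 2-carboxypiperidin-1-yl on a saturated chain carbon bound to an aromatic carbon. The group that leaves and the group that enters each carry one hydrogen-bond donor, two hydrogen-bond acceptors and no net charge. Among the measured compounds shown here, no measured pair covers a change of this kind, so the expectation rests on both measured compounds sitting at weak inhibition. The step is expected to be a number no higher from compound 1 to compound 3 (the limit leaves the size open), that is, nothing beyond the scatter. For compound 3 the estimate is 50000 nM, expected to fall between 25000 nM and 100000 nM, quite possibly reported again as a limit.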

Compound 3, half-maximal inhibitory concentration: > 50000 nM
Compound 3: only a limit was reported; the forecaster's own chance of this, stated with the estimate: 60%; the middle value sits exactly at the limit.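

Replacing 2-carboxypiperidin-1-yl with 3-carboxypyrrolidin-1-yl on a saturated chain carbon bound to an aromatic carbon gives, in this assay, an at least 1.1-fold higher number from compound 2 to compound 3 (0.07 log units; that floor lies within the scatter). Compound 3 gives > 50000 nM, a limit of the assay rather than a number, so changing the ring itself, and not only the drawn configuration, still leaves the compound at the weak-inhibition end of the read-out. The step from compound 1 to compound 3 cannot be read, because both ends of it are limits: the limit of > 50000 nM in this assay, at which 2 of the 3 values shown sit.

As far as these compounds go, how far compound 1 and compound 3 lie beyond the reach of the assay stays unknown, so any real difference between the two rings could be hidden. From the compounds shown here alone, all three compounds also carry a carboxylic acid on their saturated ring, so it remains open whether a plain piperidin-1-yl, or an amide in place of that acid, would keep the read-out at this weak end.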